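The source may hold more compounds than are shown below. What is called first, only, known or untested is meant among the compounds shown, and "the series" means these compounds.

Working notes on the naphthalene-bearing pyrazoline series.

Compound 1 `COc1cc(C2CC(c3cccc4ccccc34)=NN2C(C)=O)ccc1O` carries 4-hydroxy-3-methoxyphenyl on the saturated ring carbon of the shared core; in a functional assay on PC-3 cells (Homo sapiens) for cytotoxicity, read by sulforhodamine B assay, with a stated time of 48 h (a lower number here means a stronger inhibitor, a higher number a weaker inhibitor), compound 1 gives 2130 nM. Compound 2 `CC(=O)N1N=C(c2cccc3ccccc23)CC1c1ccco1` carries furan-2-yl at the same place, and in this assay compound 2 gives 18000 nM. Within the data shown here, the single measured step, an 8.5-fold higher number from compound 1 to compound 2 (0.93 log units; beyond the scatter), is the only comparison available for this position. Among the measured compounds shown here, compound 2 therefore stands with the highest of the two numbers measured so far, the nearest neighbour being compound 1 with the lower number.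

Compound 3 `CC(=O)N1N=C(c2cccc3ccccc23)CC1/C=C/c1ccccc1` is not yet measured. It differs from compound 2 as follows: 2-phenylethenyl in place of furan-2-yl on a saturated ring carbon. For the measured compounds named here, the one step that bears on this change is an 8.5-fold higher number from compound 1 to compound 2 (0.93 log units; beyond the scatter), which showed that swapping the group on this saturated ring carbon moves the number by a modest amount beyond the scatter. Since the only six-membered aromatic ring seen so far at this position, in compound 1, gave the lower number, compound 3 is expected to sit between the two measured numbers, closer to compound 2. The step from compound 2 to compound 3 is estimated as a 2.6-fold lower number from compound 2 to compound 3 (0.41 log units; beyond the scatter). Compound 3 is thus expected to give about 7000 nM, within a range from 2000 nM to 25000 nM.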

Compound 3, half-maximal inhibitory concentration: 21100 nM
Compound 3: the middle estimate sits 3.0-fold (0.48 log units) below what was measured; measured number inside the range.
By their numbers in this assay, from the lowest: compound 1; then compounds 2 and 3 (each within the scatter of the next).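

In this assay, the change from furan-2-yl to 2-phenylethenyl on this saturated ring carbon gives a 1.2-fold higher number from compound 2 to compound 3 (0.07 log units; within the scatter), so a six-membered aromatic ring of carbon only and a larger group, at 8 heavy atoms against 5, do not by themselves separate compound 3 from compound 2. The gap at this position now appears twice, with a 9.9-fold higher number from compound 1 to compound 3 (1.00 log units; beyond the scatter) alongside an 8.5-fold higher number from compound 1 to compound 2 (0.93 log units; beyond the scatter), and among these three compounds only the 4-hydroxy-3-methoxyphenyl group of compound 1 stands apart, while furan-2-yl and 2-phenylethenyl read alike. No evidence is available that would explain this difference or the lack of one.

Compounds 1 to 3 do not show whether the separation of compound 1 goes with its hydroxy group, its methoxy group or the two together, nor how a plain phenyl ring directly on this carbon would read. Also open, on these data alone, is whether an amine, a carboxylic acid or a saturated alkyl chain at this place would stay level with compound 2 and compound 3 or move away from them.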